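Methyl to methylsulfonyl in a small series

A few compounds are considered here, and "the series" means these few. Any claim that something is new, unique, unknown or untested is made for them only; others in the source may bear on it.

Three compounds sharing one core have numbers in a functional assay on MOLM-13 cells (Homo sapiens) for inhibition, read by MTT assay, with a stated time of 24 h; a lower number here means a stronger inhibitor, a higher number a weaker inhibitor: compound 1 (`Cc1ccc(CNc2cc(C(F)(F)F)cc3[nH]ncc23)c([N+](=O)O)c1`), compound 2 (`O=[N+](O)c1c(Cl)cccc1CNc1cc(C(F)(F)F)cc2[nH]ncc12`) and compound 3 (`O=[N+]([O-])c1ccccc1CNc1cc(C(F)(F)F)cc2[nH]ncc12`). Compound 1 gives 3430 nM, and compound 3 gives 2350 nM, a value within the scatter of the first. Compound 2 gives 7690 nM, a higher number that lies beyond the scatter from compound 1. Compound 1 therefore stands together with compound 3, apart from compound 2.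

Compound 4 (`CS(=O)(=O)c1ccc(CNc2cc(C(F)(F)F)cc3[nH]ncc23)c([N+](=O)O)c1`) has not yet been measured. It differs from compound 1 by methylsulfonyl in place of methyl on an aromatic carbon, para to a large group: methylsulfonyl in place of methyl on an aromatic carbon. For the measured compounds named here, none of the measured compounds carries methylsulfonyl, and no measured pair differs in one place, so nothing calibrates this change directly. Going by the values given here, the only guide is the spread of the series, from compound 3 at 2350 nM to compound 2 at 7690 nM.

A small move toward a higher number is expected in this assay, probably not beyond the scatter. The estimated step is a 1.3-fold higher number from compound 1 to compound 4 (0.12 log units; within the scatter). For compound 4 the expected value is 4500 nM, with an estimated range from 1700 nM to 12000 nM.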

Compound 4, half-maximal inhibitory concentration: > 20000 nM
Compound 4 was reported as a limit; the forecaster's own chance of this, stated with the estimate: 5%; at least 4.4-fold (0.64 log units) between middle value and limit.
By their numbers in this assay, from the lowest: compounds 3 and 1 (each within the scatter of the next); then compound 2. At a limit, above all of these: compound 4.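

In this assay compound 4 gives > 20000 nM, which is a limit of the assay and not a number. Methylsulfonyl in place of methyl on this aromatic carbon, para to a large group, gives an at least 5.8-fold higher number from compound 1 to compound 4 (0.76 log units; beyond the scatter), the first step in the series that isolates a single change, and it shows that this position is not indifferent to what it carries: the earlier compounds could not show this, as no two of them formed a comparable pair. The size of the step is only a lower bound, and one end of it is set by the assay limit rather than by a measured value: the limit of > 20000 nM in this assay, at which 1 of the 4 values shown sits.

The compounds shown leave open whether the loss belongs to the methylsulfonyl group specifically or would also come with other replacements of methyl at this carbon, such as a methoxy group, an amine, a carboxylic acid or a longer alkyl chain. With a single step at a single position, and that step ending at a limit, no trend across substituents at this carbon can yet be drawn.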